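Benzyl variation on the amide nitrogen of the shared core

The source may report more compounds than this note shows. Statements on the series, on what has been measured and on what is new or still open speak of the compounds shown alone.

Among the compounds with values here, compound 1 `Cc1cccc(CN2CCc3ncn(COCc4ccccc4)c3/C(=C/c3ccccc3)C2=O)c1` gives 16100 nM in a functional assay on A549 cells (Homo sapiens) for inhibition, read by MTT assay, with a stated time of 72 h (on this read-out lower numbers stand for stronger inhibition and higher numbers for weaker inhibition), the lowest of the two numbers measured so far. Compound 2 `O=C1/C(=C\c2ccc(C(F)(F)F)cc2)c2c(ncn2COCc2ccccc2)CCN1Cc1ccccc1` gives 52500 nM in this assay, a higher number beyond the scatter. Compound 3 `O=C1/C(=C\c2ccccc2)c2c(ncn2COCc2ccccc2)CCN1Cc1ccc2ccccc2c1` carries naphthalen-2-yl in place of 3-methylphenyl on a saturated chain carbon bound to an amide-type nitrogen in a ring. Within the data shown here, no measured pair shows the effect of this change, so the expectation rests on compound 1 alone. The step of a 1.3-fold lower number from compound 1 to compound 3 (0.13 log units; within the scatter) is expected to be small, toward a lower number, and possibly not beyond the scatter. Compound 3 is therefore estimated at 12000 nM in this assay, within 4000 nM to 40000 nM.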

Compound 3, half-maximal inhibitory concentration: 26400 nM
The estimate for compound 3 lay 2.2-fold (0.34 log units) below the measured number, within the range that was stated.
By their numbers in this assay, from the lowest: compounds 1, 3 and 2 (each within the scatter of the next, the first and the last beyond it).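

Naphthalen-2-yl in place of 3-methylphenyl on a saturated chain carbon bound to an amide-type nitrogen in a ring gives a 1.6-fold higher number from compound 1 to compound 3 (0.21 log units; within the scatter) in this assay. This position therefore carries a second six-membered aromatic ring with no step beyond the scatter, which neither earlier compound could show. No measurement bears on the reason for this result.

Still open, on these data alone, is how an amine, a carboxylic acid or a longer chain would read in this place. Also open, as far as these compounds go, is whether naphthalen-2-yl gives a similar step alongside the trifluoromethyl group of compound 2.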